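Pyrazole amides and urea: urea-to-amide step in SNB-75

The source may report more compounds than this note shows. Statements on the series, on what has been measured and on what is new or still open speak of the compounds shown alone.

Measured so far:
compound 1 `COc1cc(Cl)cc(-c2nn(-c3cccc(NC(=O)c4ccc(Cl)c(Cl)c4)c3)cc2-c2ccncc2)c1` — 50.6%
compound 2 `COc1cc(Cl)cc(-c2nn(-c3cccc(NC(=O)Nc4ccc(Cl)c(Cl)c4)c3)cc2-c2ccncc2)c1` — 16.2%

In a functional assay on SNB-75 cells (Homo sapiens) for inhibition, read by sulforhodamine B assay, with a stated time of 48 h, tested at 10 uM (on this read-out lower numbers stand for a stronger effect and higher numbers for a weaker effect at the one concentration tested), compound 1 gives 50.6%, and compound 2 gives 16.2%. For the measured compounds named here, the single step between them, a number 34.4 percentage points lower from compound 1 to compound 2 (beyond the scatter), is the only measured step, and it leaves compound 2 with the lowest number of the two.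

Compound 3 `COc1cc(Cl)cc(-c2nn(-c3cccc(NC(=O)c4cccc(C(F)(F)F)c4)c3)cc2-c2ccncc2)c1` is not yet measured. It differs from compound 2 by 3-(trifluoromethyl)phenyl in place of (3,4-dichlorophenyl)amino on a carbonyl carbon. Going by the values given here, this undoes the amide-type nitrogen insertion that the step from compound 1 to compound 2 introduced, while at the same time replacing the dichlorophenyl with 3-(trifluoromethyl)phenyl, so the only bearing step is a number 34.4 percentage points lower from compound 1 to compound 2 (beyond the scatter), which was large. The expectation is therefore a step back in the opposite direction, a number 28.8 percentage points higher from compound 2 to compound 3 (beyond the scatter), toward the region where compound 1 sits, with widened uncertainty because the aryl group also changes. Compound 3 is estimated at 45%, within 25% to 70%.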

Compound 3, a percentage reported as activity, at one concentration (the size of the read-out at that concentration, not a potency): 53.9%
Compound 3: middle estimate off by 8.9 percentage points, on the low side; low and high end bracket the measured number.
By their numbers in this assay, from the lowest: compound 2; then compounds 1 and 3 (each within the scatter of the next).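

In this assay the change from (3,4-dichlorophenyl)amino to 3-(trifluoromethyl)phenyl on a carbonyl carbon gives a number 37.7 percentage points higher from compound 2 to compound 3 (beyond the scatter) and shows that the low number of compound 2 is not shared by a second compound with an aryl group directly on that carbonyl carbon. Among those two compounds, the change from 3,4-dichlorophenyl to 3-(trifluoromethyl)phenyl gives a number 3.3 percentage points higher from compound 1 to compound 3 (within the scatter) so these two aryl groups cannot be told apart here at the one concentration tested. Across the three compounds, only compound 2 carries the amino-linked aryl group and only compound 2 stands apart, with no compound going against this.

Still open, going by these compounds, is whether (3-(trifluoromethyl)phenyl)amino on the same carbonyl carbon would match compound 2, and how a methylene or an oxygen in place of that nitrogen would read. No evidence at hand bears on what lies behind the separation of compound 2.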